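Sulfamoyl in place of phenyl on the anilino ring

The source may hold more compounds than are shown below. What is called first, only, known or untested is meant among the compounds shown, and "the series" means these compounds.

compound 1 `O=C1C(Nc2ccc(-c3ccccc3)cc2)=CC(=O)c2ncncc21`: 400 nM
compound 2 `O=C1C(Nc2cccc(B(O)O)c2)=CC(=O)c2ncncc21`: 9000 nM

Within the data shown here, in a functional assay on PANC-1 cells (Homo sapiens) for cytotoxicity, read by MTT assay, with a stated time of 72 h (a lower number here means a stronger inhibitor, a higher number a weaker inhibitor), compound 1 gives 400 nM, the lower of the two numbers measured so far. Compound 2 gives 9000 nM, a higher number and well beyond the usual scatter. Compound 3 `NS(=O)(=O)c1ccc(NC2=CC(=O)c3ncncc3C2=O)cc1` differs from compound 1 by sulfamoyl in place of phenyl on an aromatic carbon. Among the measured compounds shown here, no pair of measured compounds isolates this change, and compound 2 carries a different group at a different place, so the gap between compound 1 and compound 2 is only a loose guide. The step is expected to raise the number beyond the scatter. For compound 3 the estimate is 3000 nM, with a range from 800 nM to 12000 nM. This estimate corresponds to an expected step of a 7.5-fold higher number from compound 1 to compound 3 (0.88 log units; beyond the scatter).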

Compound 3, half-maximal inhibitory concentration: > 10000 nM
Compound 3: a limit, no number (the forecaster's own chance of this, stated with the estimate: 5%); middle value at least 3.3-fold (0.52 log units) from the limit.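

In this assay, sulfamoyl in place of phenyl on an aromatic carbon gives an at least 25-fold higher number from compound 1 to compound 3 (1.39 log units; beyond the scatter), the first step shown that isolates a single change at this position. Compound 3 reads > 10000 nM, which is a limit of the assay and not a number. This position therefore does not tolerate every exchange for the phenyl of compound 1, though the full size of the step stays unread: the limit of > 10000 nM in this assay, at which 1 of the 3 values shown sits.

The compounds shown do not separate losing the phenyl ring from gaining sulfamoyl. From the compounds shown here alone, it remains open whether a cyclohexyl, a methoxy or a carboxylic acid at this place would keep a number close to that of compound 1.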